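Swapping a Nitrile for Phenyl on Two Related Cores

This account rests on a few compounds, and the source may have more. Where it says the series, first, only, none or still open, it means among the compounds named here.

Compound 1 `COC1Cc2c(csc2-c2ccc(C#N)cc2)C2(CCN(Cc3ccccc3)CC2)O1` carries a cyano group on a benzene ring attached to a thiophene. In an assay on membranes from brain for displacement of a labelled ligand from Sigma non-opioid intracellular receptor 1 (Cavia porcellus), read by scintillation counting, with a stated time of 120 min (on this read-out higher numbers stand for weaker inhibition and lower numbers for stronger inhibition), compound 1 gives 0.25 nM. Compound 2 `COC1Cc2c(csc2-c2ccc(-c3ccccc3)cc2)C2(CCN(Cc3ccccc3)CC2)O1` differs in one place: phenyl in place of cyano on an aromatic carbon. In this assay compound 2 gives 30 nM, and the step of a 120-fold higher number from compound 1 to compound 2 (2.08 log units; beyond the scatter) shows how much this single change weakened binding.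

Compound 3 `COC1Cc2cc(-c3ccc(C#N)cc3)sc2C2(CCN(Cc3ccccc3)CC2)O1` is built from the same atoms as compound 1, joined differently; the difference between the two cores is not broken down here. In this assay compound 3 gives 20 nM, close to compound 2.

Compound 4 `COC1Cc2cc(-c3ccc(-c4ccccc4)cc3)sc2C2(CCN(Cc3ccccc3)CC2)O1` stands to compound 3 as compound 2 stands to compound 1, with the same change: phenyl in place of cyano on an aromatic carbon. For the measured compounds named here, only one measured example of this change exists, on the core of compound 1, so the expectation rests on it alone. The expected step, a 20-fold higher number from compound 3 to compound 4 (1.30 log units; beyond the scatter), is estimated to be somewhat smaller than the step from compound 1 to compound 2, because compound 3 already starts at 20 nM. Compound 4 is therefore expected to give about 400 nM in this assay, with a likely range from 60 nM to 3000 nM.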

Compound 4, inhibition constant: 211 nM
Compound 4: the middle estimate sits 1.9-fold (0.28 log units) above what was measured; low and high end bracket the measured number.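

Putting phenyl in place of the nitrile weakens binding again in this assay, with an 11-fold higher number from compound 3 to compound 4 (1.02 log units; beyond the scatter), so the direction of the change carries over from the core of compound 1 to the core of compound 3. The size of the change does not carry over, and the two steps differ by more than repeated measurements would explain: the same change on two cores in this assay, a 120-fold higher number (2.08 log units; beyond the scatter) from compound 1 to compound 2 and an 11-fold higher number (1.02 log units; beyond the scatter) from compound 3 to compound 4, 11-fold (1.06 log units) apart, beyond the scatter of two such steps. For the compounds shown here, this shows that the cost of the same swap depends on the core it is made on, but with only two cores it does not show why, or what the swap would cost on any further core.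

The compounds shown leave open how binding would respond to other groups in the same place, such as an amide, a carboxylic acid or a single fluorine atom. They also leave open whether the gap between the two cores would stay the same with such groups or is particular to the swap from nitrile to phenyl.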